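Ethoxy in Place of Ethyl: Expected Cell Tolerance

This account rests on a few compounds, and the source may have more. Where it says the series, first, only, none or still open, it means among the compounds named here.

Compound 2 `CCc1ccsc1CN[C@@H]1C[C@H]2C[C@@H]([C@H]1C)C2(C)C` carries an ethyl group on its five-membered aromatic ring with 1 sulfur. In an ADME assay on MDCK cells (Canis lupus familiaris) for cytotoxicity, read by microscopy, with a stated time of 48 h (a higher number here means that more compound is tolerated, a lower number that less compound is tolerated), compound 2 gives 25000 nM. Compound 1 `C=Cc1ccsc1CN[C@@H]1C[C@H]2C[C@@H]([C@H]1C)C2(C)C`, which bears a vinyl group instead, gives 50000 nM in this assay, and compound 3 `C[C@H]1[C@H](NCc2ccsc2)C[C@H]2C[C@@H]1C2(C)C`, which lacks a group on that carbon, gives 50000 nM; both numbers sit within the scatter of the result for compound 2. Within the data shown here, the only recorded change at this carbon is a 2.0-fold lower number from compound 1 to compound 2 (0.30 log units; within the scatter), which points to no real difference. Compound 4 `CCOc1ccsc1CN[C@@H]1C[C@H]2C[C@@H]([C@H]1C)C2(C)C` differs from compound 2 by ethoxy in place of ethyl on an aromatic carbon. Among the measured compounds shown here, no measured step involves an oxygen here, so only a small shift is expected, a 1.4-fold higher number from compound 2 to compound 4 (0.15 log units; within the scatter), nothing beyond the scatter. Compound 4 is therefore estimated at 35000 nM, with a range from 12500 nM to 100000 nM.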

Compound 4, minimum cytotoxic concentration: 50000 nM
Estimate against measurement, compound 4: 1.4-fold (0.15 log units) below; the range from low to high includes it.
By their numbers in this assay, from the lowest: compounds 2, 1, 3 and 4 (each within the scatter of the next).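

Adding the oxygen of ethoxy, which brings a hydrogen-bond acceptor that ethyl and vinyl lack, gives a 2.0-fold higher number from compound 2 to compound 4 (0.30 log units; within the scatter) and no change at the digits printed from compound 1 to compound 4 (within the scatter) in this assay and both steps lie within the scatter. This carbon on the five-membered aromatic ring with 1 sulfur has therefore now carried ethyl, vinyl and ethoxy with no real difference between them. No measured evidence accounts for this result. Still open, going by these compounds, is whether an amine, a carboxylic acid or a longer chain at this carbon would move the number beyond the scatter.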